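Hydroxyl for Ketone on an Inactive Anilide

This account rests on a few compounds, and the source may have more. Where it says the series, first, only, none or still open, it means among the compounds named here.

Compound 1 `CCn1c(C(=O)NCCN(C)C)ccc1C(CC)(CC)c1ccc(OCC(=O)C(C)(C)C)c(C)c1` gives 77 nM in an assay on HL-60 cells for agonist activity at vitamin D3 receptor (Homo sapiens), read by microscopy, with a stated time of 96 h; a higher number here means that more compound is needed for the effect, a lower number that less compound is needed.
Compound 2 `CCn1c(C(=O)NCCN(C)C)ccc1C(CC)(CC)c1ccc(OCC(O)C(C)(C)C)c(C)c1` gives 14 nM in this assay.
Compound 3 `CCn1c(C(=O)Nc2ccc(OC(F)(F)F)cc2)ccc1C(CC)(CC)c1ccc(OCC(=O)C(C)(C)C)c(C)c1` reaches only the limit > 50000 nM in this assay.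

Compound 2 differs from compound 1 by 1-hydroxy-2,2-dimethylpropyl in place of (tert-butyl)carbonyl on a saturated chain carbon bound to an oxygen on an aromatic ring, which gave a 5.5-fold lower number from compound 1 to compound 2 (0.74 log units; beyond the scatter). The cores of compound 1 and compound 3 differ by 4-(trifluoromethoxy)phenyl in place of 2-(dimethylamino)ethyl on an amide-type nitrogen; that change gave an at least 640-fold higher number from compound 1 to compound 3 (2.81 log units; beyond the scatter), and for compound 3 only the limit of > 50000 nM in this assay, at which 1 of the 3 values shown sits, is known. Compound 4 `CCn1c(C(=O)Nc2ccc(OC(F)(F)F)cc2)ccc1C(CC)(CC)c1ccc(OCC(O)C(C)(C)C)c(C)c1` has not been measured. It differs from compound 3 by 1-hydroxy-2,2-dimethylpropyl in place of (tert-butyl)carbonyl on a saturated chain carbon bound to an oxygen on an aromatic ring, the same change at the same place as from compound 1 to compound 2. A step of about an at least 1.6-fold lower number from compound 3 to compound 4 (0.22 log units; that floor lies within the scatter) is expected, resting on a 5.5-fold lower number from compound 1 to compound 2 (0.74 log units; beyond the scatter), although a step taken from a limit is poorly defined. Compound 4 is therefore estimated at 30000 nM, within 5000 nM to 100000 nM, most likely again reported only as a limit.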

Compound 4, half-maximal effective concentration: > 50000 nM
Compound 4: a limit, no number; the forecaster's own chance of this, stated with the estimate: 70%; middle value at least 1.6-fold (0.22 log units) from the limit.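

In this assay compound 4 gives > 50000 nM, which is a limit of the assay and not a number. With compound 3 also at a limit, the step between them cannot be read, so the change from (tert-butyl)carbonyl to 1-hydroxy-2,2-dimethylpropyl, which gave a 5.5-fold lower number from compound 1 to compound 2 (0.74 log units; beyond the scatter), is neither confirmed nor refuted on the anilide core. The swap of 2-(dimethylamino)ethyl for 4-(trifluoromethoxy)phenyl on the hydroxyl core gives an at least 3500-fold higher number from compound 2 to compound 4 (3.55 log units; beyond the scatter), and set beside the ketone pair it reads: the same change on two cores in this assay, an at least 640-fold higher number (2.81 log units; beyond the scatter) from compound 1 to compound 3 and an at least 3500-fold higher number (3.55 log units; beyond the scatter) from compound 2 to compound 4; the limit leaves it open whether they differ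

From the compounds shown here alone, the size of any hydroxyl effect on the anilide core remains open. Also open, going by these compounds, is whether a longer chain such as 3-(dimethylamino)propyl, or a phenyl ring carrying a dimethylamino group, would give a measurable value on the amide nitrogen.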